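Adding Isopropyl to a Potent Long-Chain Acid

This account rests on a few compounds, and the source may have more. Where it says the series, first, only, none or still open, it means among the compounds named here.

Measured in a functional assay (thoracic aorta) for inhibition, with Rattus norvegicus as the target; on this read-out lower numbers stand for stronger inhibition and higher numbers for weaker inhibition:
- Compound 1 `O=C(O)c1cc(CCCCCCCNS(=O)(=O)c2ccccc2)c2cccccc1-2`: 18 nM
- Compound 2 `CC(C)c1ccc2c(CCCNS(=O)(=O)c3ccccc3)cc(C(=O)O)c-2cc1`: 4800 nM

Of these two compounds, compound 1 stands lowest at 18 nM, and thus shows the stronger inhibition. The gap up to compound 2 lies well beyond the scatter. Compound 3 `CC(C)c1ccc2c(CCCCCCCNS(=O)(=O)c3ccccc3)cc(C(=O)O)c-2cc1` keeps the side chain of compound 1 and carries isopropyl in place of hydrogen on an aromatic carbon. Compound 2, at 4800 nM, also carries isopropyl but has a shorter chain, so its value cannot isolate the effect of this change. Going by the values given here, no measured pair shows the change alone. A moderate rise is therefore expected in this assay, much smaller than the gap between the two measured compounds. The expected step is a 2.2-fold higher number from compound 1 to compound 3 (0.35 log units; beyond the scatter). For compound 3 the estimated value is 40 nM, with an expected range of 8 nM to 200 nM.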

Compound 3, half-maximal inhibitory concentration: 120 nM
Compound 3: middle estimate off by 3.0-fold (0.48 log units), on the low side, within the range that was stated.
By their numbers in this assay, from the lowest: compound 1; then compound 3; then compound 2.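

In this assay, going by these compounds alone, isopropyl in place of hydrogen on an aromatic carbon gives a 6.7-fold higher number from compound 1 to compound 3 (0.82 log units; beyond the scatter) and so shows this change on its own for the first time. This position accepts the isopropyl group at a modest cost on the long side chain, and compound 3 at 120 nM still stands far lower than compound 2, which carries the same group on a shorter chain, at 4800 nM. Nothing in the available data accounts for the rise.

Going by these compounds, it remains open whether methyl or tert-butyl on this aromatic carbon would give a smaller or larger step than isopropyl. On these data alone, it is equally open whether the same change would have a similar size on the shorter chain of compound 2, or with an amide in place of the carboxylic acid.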